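Turning One Double Bond Around

The source may report more compounds than this note shows. Statements on the series, on what has been measured and on what is new or still open speak of the compounds shown alone.

In a functional assay on NALM-6 cells (Homo sapiens) for cytotoxicity, read by MTT assay, with a stated time of 46 h (a lower number here means a stronger inhibitor, a higher number a weaker inhibitor), compound 1 `O=C1/C(=C\c2ccccc2)C(c2ccccc2)Oc2ccccc21` reports > 1000000 nM as a limit of the assay and not a number. In this assay, going by the values given here, compound 2 `O=C1/C(=C/c2ccccc2)C(c2ccccc2)Oc2ccc(O)cc21` gives 8700 nM as the only true number so far. Compound 3 `O=C1/C(=C\c2ccccc2)C(c2ccccc2)Oc2ccc(O)cc21` differs from compound 2 in a single way (the two compounds have the same atoms and bonds; at least one stereo element is drawn with a configuration in one of them and without one in the other: 1 of 2 stereo elements differ; a double bond is drawn E in compound 2 and Z in compound 3): a double bond is drawn E in compound 2 and Z in compound 3. Among the compounds with values here, no measured pair shows what this switch does in this assay so only a moderate weakening is expected, and a small gain remains possible. The estimated step of a 2.3-fold higher number from compound 2 to compound 3 (0.36 log units; beyond the scatter) is therefore modest. Compound 3 is expected at 20000 nM (estimated range 5000 nM to 100000 nM).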

Compound 3, half-maximal inhibitory concentration in the NALM-6 assay: 58800 nM
Compound 3: the middle estimate sits 2.9-fold (0.47 log units) below what was measured, and the stated range covers the measured number.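

In the NALM-6 assay the direction of the double bond clearly counts, with a 6.8-fold higher number from compound 2 to compound 3 (0.83 log units; beyond the scatter), while in a physicochemical assay for lipophilicity, read by HPLC (a higher number here means a more lipophilic compound, a lower number a more polar compound), the same switch gives a number 0.05 log units lower from compound 2 to compound 3 (within the scatter), with compound 2 at 3.5 and compound 3 at 3.45. Keeping the double bond as in compound 3, the hydroxy group also makes a large difference in the NALM-6 assay, with an at least 17-fold lower number from compound 1 to compound 3 (1.23 log units; beyond the scatter). In the NALM-6 assay compound 1 gives > 1000000 nM, a limit of the assay and not a number, so that step is only a minimum.

From the compounds shown here alone, it remains open whether an amine or a methoxy group could replace the hydroxy group, and whether either would respond to the double-bond switch in the same way.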